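Cyclopropane-dicarboxamide anilides: fluorophenyl to bromophenyl swap

The source may hold more compounds than are shown below. What is called first, only, known or untested is meant among the compounds shown, and "the series" means these compounds.

Measured so far in a functional assay on A549 cells (Homo sapiens) for inhibition, read by CCK-8 assay, with a stated time of 72 h, tested at 1 uM; on this read-out lower numbers stand for less inhibition of growth and higher numbers for more inhibition of growth at the one concentration tested:
- compound 1 `CN(C)C(=O)c1cc2cnc(Nc3ccc(NC(=O)C4(C(=O)Nc5ccc(F)cc5)CC4)cc3)nc2n1C1CCCC1` gives 86.6%
- compound 2 `CN(C)C(=O)c1cc2cnc(Nc3ccc(NC(=O)C4(C(=O)Nc5cccc(F)c5)CC4)cc3)nc2n1C1CCCC1` gives 33.2%
- compound 3 `CN(C)C(=O)c1cc2cnc(Nc3ccc(NC(=O)C4(C(=O)Nc5ccc(Cl)c(C(F)(F)F)c5)CC4)cc3)nc2n1C1CCCC1` gives 1.1%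

Compound 1 stands highest of the three on this read-out; compound 2 is nearest, compound 3 furthest, and both gaps lie beyond the scatter. The measured steps: a number 53.4 percentage points lower from compound 1 to compound 2 (beyond the scatter); a number 85.5 percentage points lower from compound 1 to compound 3 (beyond the scatter); a number 32.1 percentage points lower from compound 2 to compound 3 (beyond the scatter).

The next compound is compound 4 `CN(C)C(=O)c1cc2cnc(Nc3ccc(NC(=O)C4(C(=O)Nc5cccc(Br)c5)CC4)cc3)nc2n1C1CCCC1`. Its change from compound 1 reads (3-bromophenyl in place of 4-fluorophenyl on an amide-type nitrogen). The step that bears most directly on it is the move from compound 1 to compound 2, which also leaves the 4-fluorophenyl for a 3-substituted phenyl and cost a number 53.4 percentage points lower from compound 1 to compound 2 (beyond the scatter). Among the compounds with values here, compound 4 carries a bromine rather than a fluorine at that position; no measured pair isolates that exchange, so its own effect is unknown. Within the data shown here, on the one relevant step, a large drop beyond the scatter is expected, of about a number 58.6 percentage points lower from compound 1 to compound 4 (beyond the scatter).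

For compound 4 the estimate is 28%, with a range from 3% to 60%.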

Compound 4, percent growth inhibition at one concentration: 20.2%
Compound 4: middle estimate off by 7.8 percentage points, on the high side, within the range that was stated.
By their numbers in this assay, from the lowest: compound 3; then compound 4; then compound 2; then compound 1.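

In this assay, the 3-bromophenyl on the amide-type nitrogen gives a number 66.4 percentage points lower from compound 1 to compound 4 (beyond the scatter), so a second 3-substituted phenyl also falls far short of the 4-fluorophenyl. Within the data shown here, the first isolated halogen exchange at this position, bromo in place of fluoro on an aromatic carbon, gives a number 13 percentage points lower from compound 2 to compound 4 (beyond the scatter), while the change from the 4-chloro-3-(trifluoromethyl)phenyl gives a number 19.1 percentage points higher from compound 3 to compound 4 (beyond the scatter); both steps are modest but beyond the scatter. No measured evidence bears on why these numbers differ.

On these data alone, whether the high value of compound 1 depends on the fluorine itself remains open, as no unsubstituted phenyl stands for comparison. As far as these compounds go, it is also open how this position would respond to a group other than a substituted phenyl, such as a cyclohexyl or an amine-bearing chain.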